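Ring methyl removal and cell toxicity across two cores

The compounds below may be only part of what the source reports. "The series", "measured", "known", "first", "only" and "open" are said of these compounds alone.

Of the compounds shown here, three have been measured. Compound 1 `COc1cccc(-c2nnc(-c3cc([N+](=O)[O-])cn3C)o2)c1` gives 299000 nM in an ADME assay on Vero cells (Chlorocebus sabaeus) for cytotoxicity, read by MTT assay, with a stated time of 72 h; a higher number here means a weaker inhibitor, a lower number a stronger inhibitor. Compound 2 `Cc1ccc(-c2nnc(-c3cc([N+](=O)[O-])cn3C)o2)s1` gives 98300 nM in this assay, and compound 3 `Cc1ccc(-c2nnc(-c3cc([N+](=O)[O-])c[nH]3)o2)s1` gives 329000 nM. The difference between the core of compound 1 and the core of compound 2 is not broken down here; their two values stand apart from each other, while compound 1 and compound 3 give values that lie within the usual scatter of one another.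

Compound 3 arises from compound 2 by one change, (hydrogen in place of methyl on an aromatic nitrogen), and this gave a 3.3-fold higher number from compound 2 to compound 3 (0.52 log units; beyond the scatter), a modest step beyond the scatter.

Compound 4 `COc1cccc(-c2nnc(-c3cc([N+](=O)[O-])c[nH]3)o2)c1` is not yet measured. It arises from compound 1 by hydrogen in place of methyl on an aromatic nitrogen. The place of the change is the same, word for word, as for the pair above, so this is the same change on the other core.

Compound 4 is therefore expected to show a step of about a 2.3-fold higher number from compound 1 to compound 4 (0.37 log units; beyond the scatter), resting on compound 2 and compound 3 and their step of a 3.3-fold higher number from compound 2 to compound 3 (0.52 log units; beyond the scatter). For the measured compounds named here, the value for compound 4 is estimated at 700000 nM, expected to fall between 250000 nM and 2000000 nM; the single earlier step may not carry over to the core of compound 1 exactly, so the range is kept wide.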

Compound 4, half-maximal inhibitory concentration: 429000 nM
Beside the measured number, compound 4's estimate is 1.6-fold (0.21 log units) above it; low and high end bracket the measured number.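

On the second core, hydrogen in place of methyl on an aromatic nitrogen gives a 1.4-fold higher number from compound 1 to compound 4 (0.16 log units; within the scatter) in this assay, so this step cannot be told from repeat measurement noise. Set beside the earlier pair, the two steps do not separate from each other: the same change on two cores in this assay, a 3.3-fold higher number (0.52 log units; beyond the scatter) from compound 2 to compound 3 and a 1.4-fold higher number (0.16 log units; within the scatter) from compound 1 to compound 4, 2.3-fold (0.37 log units) apart, within the scatter of two such steps. This shows no measurable disagreement between the two cores for this change, but with one step beyond the scatter and the other within it, two pairs do not fix the size of the step or show that it would hold on any further core.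

The compounds shown carry only methyl or hydrogen on the aromatic nitrogen, so it remains open how a longer chain, or a chain ending in an amine or a carboxylic acid, would read at that place. Also open, on these data alone, is whether the same comparison would hold with a nitrile in place of the nitro group.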